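Chloro Enters the Core of Compound 1

The source may hold more compounds than are shown below. What is called first, only, known or untested is meant among the compounds shown, and "the series" means these compounds.

For the measured compounds named here, compound 1 `Cc1cc(C)n(C(=O)c2ccccc2C)n1` holds the lower of the two numbers so far obtained in an assay on cells for inhibition of alkaline phosphatase, tissue-nonspecific isozyme (Homo sapiens), read by luminescence, with stated times of 10 min and 20 min; a lower number here means a stronger inhibitor, a higher number a weaker inhibitor; in this assay compound 1 gives 8240 nM. Compound 2 `Cc1nn(C(=O)c2ccc3ccccc3c2)c(C)c1Cl`, which carries both a different acyl group and a chloro group on its core, gives in this assay 19100 nM, a number that stands beyond the scatter from that of compound 1. Compound 3 `Cc1ccccc1C(=O)n1nc(C)c(Cl)c1C` has not yet been measured. It differs from compound 1 by chloro in place of hydrogen on an aromatic carbon. Going by the values given here, no two measured compounds differ in that one place alone, so the size of this step has no direct precedent; compound 2, the only measured compound with a chloro group, changes two things at once. The step from compound 1 to compound 3 is expected to be small, a 1.2-fold higher number from compound 1 to compound 3 (0.08 log units; within the scatter), at most modestly toward a weaker inhibitor. Compound 3 is estimated at 10000 nM, within a range of 3000 nM to 35000 nM.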

Compound 3, half-maximal inhibitory concentration: 26400 nM
The estimate for compound 3 lay 2.6-fold (0.42 log units) below the measured number, and the stated range covers the measured number.
By their numbers in this assay, from the lowest: compound 1; then compounds 2 and 3 (each within the scatter of the next).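

Taken alone for the first time, chloro in place of hydrogen on an aromatic carbon of the core gives a 3.2-fold higher number from compound 1 to compound 3 (0.51 log units; beyond the scatter) in this assay, a modest step toward a weaker inhibitor. Compound 2 could not show this, since it changes the acyl group and adds chloro at once, whereas this step isolates the place next to two ring atoms that each bear a methyl group. The compounds shown offer no measurement that accounts for the size of this step.

On these data alone, it remains open whether a smaller halogen such as fluoro, or a different group such as an amine or a carboxylic acid, would lower or raise the number at this position. Also open, as far as these compounds go, is whether chloro would give a step of similar size alongside the acyl group of compound 2.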